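Repositioning the chlorine on the aryl group of compound 2

The source may hold more compounds than are shown below. What is called first, only, known or untested is meant among the compounds shown, and "the series" means these compounds.

Working notes on the series. Three compounds have numbers in an assay on Sf9 cells for inhibition of protein deacetylase HDAC6 (Homo sapiens), read by fluorescence, with a stated time of 40 min, tested at 100 nM; on this read-out lower numbers stand for less inhibition and higher numbers for more inhibition at the one concentration tested (going by the name of the read-out). Compound 1 `Cc1ccc(-n2nc(-c3ccccc3)nc2CNc2ccc(C(=O)NO)cc2)cc1` gives 60.7% in this assay. Compound 2 `O=C(NO)c1ccc(NCc2nc(-c3cccc(Cl)c3)nn2-c2ccccc2)cc1` gives 61.2% in this assay. Compound 3 `NC(=O)c1ccc(NCc2nc(-c3ccccc3)nn2-c2ccccc2)cc1` gives -4.4% in this assay.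

Compound 2 stands highest of the three numbers, but its nearest neighbour, compound 1, sits within the usual scatter of it, so the two cannot be ordered. The gap to compound 3 lies well beyond the scatter; compound 3 carries a carboxamide where compound 1 and compound 2 carry a hydroxamic acid, and compound 3 shows essentially no inhibition.

Compound 4 `O=C(NO)c1ccc(NCc2nc(-c3ccccc3Cl)nn2-c2ccccc2)cc1` has not been measured. It differs from compound 2 in one place: 2-chlorophenyl in place of 3-chlorophenyl on an aromatic carbon. Within the data shown here, no pair of measured compounds isolates this change, so no measured step guides it. Compound 1 and compound 2 differ in two places at once and sit within the scatter of each other, which gives no hint that the chlorophenyl placement moves the read-out strongly. The step from compound 2 to compound 4 is therefore expected to be small, with none beyond the scatter in either direction as the most likely outcome, a number 4.2 percentage points lower from compound 2 to compound 4 (within the scatter). For compound 4 the estimate in this assay is 57%, with a range from 40% to 72%.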

Compound 4, a percentage reported as inhibition, at one concentration (the size of the read-out at that concentration, not a potency): 75%
Compound 4: middle estimate off by 18 percentage points, on the low side; measured number above the stated range.
By their numbers in this assay, from the lowest: compound 3; then compounds 1 and 2 (each within the scatter of the next); then compound 4.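

In this assay, swapping 3-chlorophenyl for 2-chlorophenyl on the aromatic carbon of the five-membered aromatic ring with 3 nitrogen gives a number 13.8 percentage points higher from compound 2 to compound 4 (beyond the scatter), a modest step, and it shows that the read-out at this position depends on where the chlorine sits on the aryl group, even though the two groups have the same heavy atoms and the same counts of hydrogen-bond donors and acceptors. The earlier compounds shown here could not show this: compound 1 and compound 2 differ in two places at once, and no measured pair isolated the placement of the chlorine. No measurement here bears on what lies behind the step.

The compounds shown leave open whether the higher number belongs to the chlorine itself or to any group placed there, which a comparison of 2-chlorophenyl with 2-fluorophenyl, 2-methylphenyl or 2-methoxyphenyl at this position would begin to separate. They also leave open how 4-chlorophenyl would stand against the 2-chlorophenyl and 3-chlorophenyl groups, so the placement of the chlorine is known at only two sites on the aryl ring.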